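Diyne alcohol series: adding a 2-oxopropyl group

The compounds below may be only part of what the source reports. "The series", "measured", "known", "first", "only" and "open" are said of these compounds alone.

Measured so far:
compound 1, `C=CCCCCCCCC#CC#CCO`: 3.9 ug/mL
compound 2, `CCCCCCCC#CC#CCO`: 5.48 ug/mL

Of the compounds shown here, two have been measured in a functional assay on A549 cells (Homo sapiens) for cytotoxicity; on this read-out higher numbers stand for an effect only at larger amounts of compound and lower numbers for an effect already at smaller amounts. Compound 1 (`C=CCCCCCCCC#CC#CCO`) gives 3.9 ug/mL and compound 2 (`CCCCCCCC#CC#CCO`) gives 5.48 ug/mL. Going by the values given here, the single step, a 1.4-fold higher number from compound 1 to compound 2 (0.15 log units; within the scatter), shows the two values lie within the scatter of each other, so compound 2 stands at a number indistinguishable from that of compound 1.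

Compound 3 (`CCCCCCCC#CC#CC(O)CC(C)=O`) is not yet measured. The change from compound 2 is 2-oxopropyl in place of hydrogen on a saturated chain carbon bound to an oxygen on a saturated carbon and a triple-bonded carbon. Among the compounds with values here, no measured step touches this position or this kind of group; the only step in hand, a 1.4-fold higher number from compound 1 to compound 2 (0.15 log units; within the scatter), concerns a distant chain end and cannot be carried over. With nothing to build on, no shift beyond the scatter is expected in this assay, and the range is kept wide. Compound 3 is estimated at 6 ug/mL (2.5 ug/mL to 15 ug/mL), an expected step of a 1.1-fold higher number from compound 2 to compound 3 (0.04 log units; within the scatter).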

Compound 3, concentration for half-maximal effect: 4.17 ug/mL
The estimate for compound 3 lay 1.4-fold (0.16 log units) above the measured number; the range from low to high includes it.
By their numbers in this assay, from the lowest: compounds 1, 3 and 2 (each within the scatter of the next).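

In this assay, 2-oxopropyl in place of hydrogen on a saturated chain carbon bound to an oxygen on a saturated carbon and a triple-bonded carbon gives a 1.3-fold lower number from compound 2 to compound 3 (0.12 log units; within the scatter), so this position accepts a group of 4 heavy atoms with no shift beyond the scatter. Going by these compounds alone, the earlier step, a 1.4-fold higher number from compound 1 to compound 2 (0.15 log units; within the scatter), exchanged vinyl elsewhere on the chain and left this carbon untouched, so this is the first reading at this position. No supporting measurement is available to account for this result.

Going by these compounds, whether an amine, a carboxylic acid or a longer chain on this carbon would move the number beyond the scatter stays open. Also open, on these data alone, is whether the carbonyl of 2-oxopropyl matters, as a plain propyl group on the same carbon would show.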